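Pyridazine to pyrimidine swap on a carboxylated heteroaryl ring

The source may report more compounds than this note shows. Statements on the series, on what has been measured and on what is new or still open speak of the compounds shown alone.

Measured compounds:
compound 1, `CS(=O)(=O)c1ccc(OCc2ccc(F)cc2F)c(C2=C(c3cccc(C(=O)O)c3)CCC2)c1`, 15.9 nM
compound 2, `O=C(O)c1cc(C2=C(c3cc(Cl)ccc3OCc3ccccc3)CCC2)cnn1`, 39.8 nM

In an assay on isolated protein for inhibition of prostaglandin E2 receptor EP1 subtype (Homo sapiens) (a lower number here means a stronger inhibitor, a higher number a weaker inhibitor), compound 1 gives 15.9 nM. In the same assay compound 2 gives 39.8 nM, the highest of the two numbers; the nearest, compound 1, shows a value that is lower by an amount beyond the usual scatter.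

Compound 3, `O=C(O)c1ccnc(C2=C(c3cc(Cl)ccc3OCc3ccccc3)CCC2)n1`, has not yet been measured in this assay. It differs from compound 2 in one place: 4-carboxypyrimidin-2-yl in place of 6-carboxypyridazin-4-yl on a double-bonded ring carbon. The two have the same atoms, joined differently; the group leaving and the group entering each carry one hydrogen-bond donor and three hydrogen-bond acceptors, so the change is a rearrangement of the heteroaryl ring rather than a change in composition.

Among the measured compounds shown here, no step between two measured compounds of this kind is available, so the expectation rests on compound 2 alone. The step from compound 2 to compound 3 is expected to be small, either within the scatter or a modest move toward a higher number, a 1.5-fold higher number from compound 2 to compound 3 (0.18 log units; within the scatter). For compound 3 the estimate in this assay is 60 nM, with a range from 20 nM to 200 nM.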

Compound 3, half-maximal inhibitory concentration in the prostaglandin E2 receptor EP1 subtype assay: 158 nM
Beside the measured number, compound 3's estimate is 2.6-fold (0.42 log units) below it; low and high end bracket the measured number.
By their numbers in the prostaglandin E2 receptor EP1 subtype assay, from the lowest: compound 1; then compound 2; then compound 3.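

In the prostaglandin E2 receptor EP1 subtype assay, the step for 4-carboxypyrimidin-2-yl in place of 6-carboxypyridazin-4-yl is a 4.0-fold higher number from compound 2 to compound 3 (0.60 log units; beyond the scatter) and lies beyond the scatter, so this place on a double-bonded ring carbon responds to how the same atoms are joined, and not only to which atoms are present. Among the compounds shown here, compound 2 was the only earlier compound on this core, and it could not show this sensitivity on its own, whereas the pair now shows that a rearrangement of the heteroaryl ring alone, with the counts of heavy atoms, donors and acceptors unchanged, is enough to move the number. In a physicochemical assay for lipophilicity (on this read-out higher numbers stand for higher lipophilicity and lower numbers for lower lipophilicity), compound 3 gives 0.8 and compound 2 gives "not determined" (no result reported) on that read-out, so the step between them there cannot be read, and nothing shown accounts for the step in binding.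

The compounds shown leave open how other heteroaryl rings would behave at this place on the same core, such as a carboxypyrazinyl ring, or a tetrazole in place of the carboxylic acid. They also leave open whether the same rearrangement would cost as much on the core of compound 1, which differs from compound 2 in more than one place.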